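Phenyl in Place of Trimethoxyphenyl: Expected Edema Inhibition

The source may hold more compounds than are shown below. What is called first, only, known or untested is meant among the compounds shown, and "the series" means these compounds.

Measured compounds:
compound 1, `C/C(=N\O)c1ccc(NC(=O)CSc2nnc(-c3ccccc3)n2-c2ccccc2)cc1`, 63%
compound 2, `COc1cc(-c2nnc(SCC(=O)Nc3ccc(C(C)=O)cc3)n2-c2ccccc2)cc(OC)c1OC`, 55%

Of the compounds shown here, two have been measured in a functional assay on the whole organism (strain albino) for inhibition, with Rattus norvegicus as the target, read by paw edema, with stated times of 30 min and 3 h, at a dose of 0.28 mmol/kg by the oral route; a lower number here means less inhibition, a higher number more inhibition at the dose given (going by the name of the read-out). Compound 1 carries a phenyl group on the five-membered aromatic ring and gives 63%. Compound 2 carries a 3,4,5-trimethoxyphenyl group at that position and gives 55%. Of the two numbers, that of compound 2 is the lower, but the gap to compound 1 lies within the usual scatter of this kind of measurement, so the two compounds cannot be ranked against each other.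

The step to compound 3, `CC(=O)c1ccc(NC(=O)CSc2nnc(-c3ccccc3)n2-c2ccccc2)cc1`, is the change (phenyl in place of 3,4,5-trimethoxyphenyl on an aromatic carbon). Within the data shown here, no pair of measured compounds differing in exactly one place is available, so the size of this step is not known from the data. Compound 1, which also bears a phenyl group at this position, gives a number close to that of compound 2.

On this basis compound 3 is expected to show a step of a number 5 percentage points higher from compound 2 to compound 3 (within the scatter) that stays within the scatter. The estimate for compound 3 in this assay is 60%, in the range 46% to 72%.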

Compound 3, a percentage reported as inhibition, in the whole organism at one dose (the size of the read-out at that dose, not a potency): 62%
Compound 3: middle estimate off by 2 percentage points, on the low side; the range from low to high includes it.
By their numbers in this assay, from the lowest: compounds 2, 3 and 1 (each within the scatter of the next).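

In this assay, the exchange of 3,4,5-trimethoxyphenyl for phenyl now has a measured size, a number 7 percentage points higher from compound 2 to compound 3 (within the scatter), so this position, on an aromatic carbon of a five-membered aromatic ring with 3 nitrogen, accepts either group without a readable difference at this dose. Compound 3 also supplies a second single change, a group of 3 heavy atoms in place of a group of 4 heavy atoms on an aromatic carbon, and this step, a number 1 percentage points lower from compound 1 to compound 3 (within the scatter), cannot be told from the scatter either, so neither of the two changes separates the compounds in this read-out. Nothing else measured on these compounds bears on what lies behind these readings.

The compounds shown leave open whether a different kind of group on this carbon, such as an amine, a carboxylic acid or a longer chain in place of the phenyl, would produce a step beyond the scatter. They also leave open whether the two changes would remain indistinguishable at other doses, since each compound is described here at a single dose.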